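Methoxy in place of chloro on the aryl of compound 2

A few compounds are considered here, and "the series" means these few. Any claim that something is new, unique, unknown or untested is made for them only; others in the source may bear on it.

Two compounds of the series have numbers in a functional assay on L1210 cells (Mus musculus) for inhibition, read by cell counting, with a stated time of 2 days; on this read-out higher numbers stand for weaker inhibition and lower numbers for stronger inhibition. Compound 1 `COc1ccc(-c2csc3nc(-c4cccc(N)c4)cn23)cc1` gives 19000 nM. Compound 2 `C=C(Br)C(=O)Nc1cccc(-c2cn3c(-c4ccc(Cl)cc4)csc3n2)c1` gives 1900 nM, the lowest of the two numbers; its nearest neighbour is compound 1, and that gap lies beyond the usual scatter. Compound 3 `C=C(Br)C(=O)Nc1cccc(-c2cn3c(-c4ccc(OC)cc4)csc3n2)c1` is not yet measured. It differs from compound 2 in one place: methoxy in place of chloro on an aromatic carbon. Among the measured compounds shown here, no pair of measured compounds shows this change alone, so its size cannot be read from the series; compound 1 carries the methoxy group but differs from compound 3 elsewhere as well, so its value does not stand for this step. The step from compound 2 to compound 3 is expected to stay within the scatter, with no clear direction, estimated as a 1.3-fold higher number from compound 2 to compound 3 (0.12 log units; within the scatter). Compound 3 is accordingly expected to give 2500 nM in this assay, within a range from 1000 nM to 6500 nM.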

Compound 3, half-maximal inhibitory concentration: 200 nM
For compound 3 the middle estimate is 13-fold (1.10 log units) above the measured one; the measured number lies below the stated range.
By their numbers in this assay, from the lowest: compound 3; then compound 2; then compound 1.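

In this assay, among the compounds shown here, 4-chlorophenyl to 4-methoxyphenyl is the first change at this position that can be read alone, and it is not neutral: a 9.5-fold lower number from compound 2 to compound 3 (0.98 log units; beyond the scatter). With the methoxy group held in place, (1-bromoethenyl)carbonyl on the nitrogen on the aromatic ring also gets its first reading, a 95-fold lower number from compound 1 to compound 3 (1.98 log units; beyond the scatter), so both places on the series now carry a step beyond the scatter. Nothing at hand gives a reason for either step.

As far as these compounds go, whether the lower number belongs to methoxy alone, or also comes with hydroxy, ethoxy or dimethylamino at this place, stays open. Also open, from the compounds shown here alone, is whether the step from chloro to methoxy keeps its size when the nitrogen carries hydrogen in place of (1-bromoethenyl)carbonyl, as in compound 1.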